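The source may report more compounds than this note shows. Statements on the series, on what has been measured and on what is new or still open speak of the compounds shown alone.

Measured compounds:
compound 1, `CCCCCCCCCCCCCCOC(=O)CCC(=O)N1CCN(CCCOc2cc3c(Nc4ccc(F)c(Cl)c4)ncnc3cc2OC)CC1`, with 92.3%
compound 2, `CCCCCCCCCCCCCCCOC(=O)CCC(=O)N1CCN(CCCOc2cc3c(Nc4ccc(F)c(Cl)c4)ncnc3cc2OC)CC1`, with 91.2%
compound 3, `CCCCCCCCCCCCCCCCOC(=O)CCC(=O)N1CCN(CCCOc2cc3c(Nc4ccc(F)c(Cl)c4)ncnc3cc2OC)CC1`, with 91.7%

The three compounds were tested in a functional assay on A549 cells (Homo sapiens) for cytotoxicity, read by MTT assay, with a stated time of 24 h, tested at 20 uM; a higher number here means a weaker effect of the compound at the concentration tested, a lower number a stronger effect. Compound 3 stands second highest of the three numbers in this assay; its nearest neighbour is compound 2 and its furthest is compound 1, and both gaps lie within the scatter, as the steps of a number 0.5 percentage points higher from compound 2 to compound 3 (within the scatter) and a number 0.6 percentage points lower from compound 1 to compound 3 (within the scatter) show.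

Compound 4, `CCCCCCCCCCCCCCCCCCCOC(=O)CCC(=O)N1CCN(CCCOc2cc3c(Nc4ccc(F)c(Cl)c4)ncnc3cc2OC)CC1`, has not yet been measured. It differs from compound 3 in one place: propyl in place of hydrogen on a saturated chain carbon, ten or more bonds along the chain from an oxygen next to a carbonyl group.

The measured steps that bear on this change are all lengthenings of the same chain at the same place: a number 1.1 percentage points lower from compound 1 to compound 2 (within the scatter), a number 0.5 percentage points higher from compound 2 to compound 3 (within the scatter) and a number 0.6 percentage points lower from compound 1 to compound 3 (within the scatter). None of them went beyond the scatter, in either direction. Compound 4 is therefore expected to give a number in this assay close to that of compound 3, with the estimated step of a number 0.2 percentage points lower from compound 3 to compound 4 (within the scatter) being none beyond the scatter. The estimate for compound 4 in this assay is 91.5%, within a range from 85% to 97%.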

Compound 4, a percentage reported as activity, at one concentration (the size of the read-out at that concentration, not a potency): 94.8%
Compound 4: the middle estimate sits 3.3 percentage points below what was measured; low and high end bracket the measured number.
By their numbers in this assay, from the lowest: compounds 2, 3, 1 and 4 (each within the scatter of the next).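

In this assay, propyl in place of hydrogen on this saturated chain carbon gives a number 3.1 percentage points higher from compound 3 to compound 4 (within the scatter), while butyl and pentyl give a number 3.6 percentage points higher from compound 2 to compound 4 (within the scatter) and a number 2.5 percentage points higher from compound 1 to compound 4 (within the scatter). These are larger than the earlier steps at this position, yet each remains within the scatter, so no effect of chain length can be told across the four compounds, even with the longest chain shown. Nothing at hand bears on why the numbers stay so close together.

The compounds leave open whether a much shorter chain would give a different number in this assay. They also leave open how a chain carrying an amine or a carboxylic acid would behave.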